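A Pyridine Ether Tested Against a Stability Ceiling

The source may hold more compounds than are shown below. What is called first, only, known or untested is meant among the compounds shown, and "the series" means these compounds.

Compound 1 `C=CC(=O)NCc1coc(-c2c(N)ncnc2Nc2ccc(OCc3cccc(F)c3)c(Cl)c2)n1` was tested in an in vitro ADME assay on microsomes from liver (Canis lupus familiaris) for metabolic stability, tested at 5 uM; a lower number here means that the compound disappears faster, a higher number that the compound lasts longer. In this assay compound 1 gives > 1.66 h, which is a limit of the assay rather than a number. Compound 2 `C=CC(=O)NCc1coc(-c2c(N)ncnc2Nc2ccc(Oc3cc(Cl)ccc3Cl)c(Cl)c2)n1` carries a 2,5-dichlorophenyl in place of 3-fluorobenzyl on an oxygen on an aromatic ring. In this assay compound 2 gives > 1.66 h, again a limit. Compound 3 `C=CC(=O)NCc1coc(-c2c(N)ncnc2Nc2ccc(Oc3ccc(F)cc3)c(Cl)c2)n1` carries a 4-fluorophenyl in place of 3-fluorobenzyl on that oxygen. In this assay compound 3 gives > 1.66 h, also a limit. Because all three values sit at the limit of > 1.66 h in this assay, at which 3 of the 3 values shown sit, the steps a step that the two limits leave unreadable from compound 1 to compound 2 and a step that the two limits leave unreadable from compound 1 to compound 3 cannot be read, and neither can a step that the two limits leave unreadable from compound 2 to compound 3. Within the data shown here, compound 1 therefore stands at the limit of the assay, with no measured compound placed above or below it.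

Compound 4 `C=CC(=O)NCc1coc(-c2c(N)ncnc2Nc2ccc(Oc3cccnc3)c(Cl)c2)n1` has not yet been measured. It differs from compound 1 by pyridin-3-yl in place of 3-fluorobenzyl on an oxygen on an aromatic ring. The three measured steps all concern exchanges of the group on this same oxygen, yet none of them has a readable size, so they give no direction for the new exchange. Compound 4 is expected to give about 1.8 h, within a range of 1 h to 3.5 h, in this assay. The expected step that the limit leaves unreadable from compound 1 to compound 4 is thus estimated as none beyond the scatter.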

Compound 4, half-life: 0.65 h
Compound 4: middle estimate off by 2.8-fold (0.44 log units), on the high side, outside the stated range (below it).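

Among these compounds, this oxygen position was silent until now: every exchange among compounds 1, 2 and 3 ended at the limit of this assay and could not be read, whereas pyridin-3-yl gives the first change with a direction, an at least 2.5-fold lower number from compound 1 to compound 4 (0.40 log units; beyond the scatter). The same change appears against the two groups joined directly to the oxygen through a ring of carbon only, an at least 2.5-fold lower number from compound 3 to compound 4 (0.40 log units; beyond the scatter) and an at least 2.5-fold lower number from compound 2 to compound 4 (0.40 log units; beyond the scatter), so the lower number in compound 4 is not confined to the comparison with the 3-fluorobenzyl group. Each of these steps gives only a minimum size, because the other compound in each pair stands at a limit and not at a number: the limit of > 1.66 h in this assay, at which 3 of the 4 values shown sit.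

The compounds shown cannot separate the effect of the ring nitrogen from the loss of the halogens, and an unsubstituted phenyl on the same oxygen would bear directly on that question. Also open, on these data alone, is whether the place of the nitrogen or the length of the link matters, which pyridin-4-yl and pyridin-3-ylmethyl on this oxygen would test.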